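Phenyl for Methyl on a Ring Nitrogen of Compound 1

The source may hold more compounds than are shown below. What is called first, only, known or untested is meant among the compounds shown, and "the series" means these compounds.

Of the compounds shown here, two sharing one core have been measured so far. Compound 1, `COc1ccc(Cl)cc1C(=O)Nc1ccc(C2=NN(C)C(c3ccccc3[N+](=O)[O-])C2)cc1`, was tested in a functional assay on the whole organism (plasma, strain albino) for inhibition, with Rattus norvegicus as the target, with stated times of 1 h and 4 h, at a dose of 50 mg/kg by the oral route (a higher number here means a stronger effect of the compound at the dose given, a lower number a weaker effect), and in that test compound 1 gives 91.3%. Compound 2, `COc1ccc(Cl)cc1C(=O)Nc1ccc(C2=NN(C)C(c3ccc([N+](=O)[O-])cc3)C2)cc1`, in this assay compound 2 gives 83.2%. Among the compounds with values here, the one step between them, a number 8.1 percentage points lower from compound 1 to compound 2 (within the scatter), concerns the nitrophenyl group on a saturated ring carbon. Within the data shown here, on these two numbers compound 1 stands highest, with compound 2 as its only neighbour at a distance within the scatter, so the two cannot be ranked.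

Compound 3, `COc1ccc(Cl)cc1C(=O)Nc1ccc(C2=NN(c3ccccc3)C(c3ccccc3[N+](=O)[O-])C2)cc1`, differs from compound 1 in a single place: phenyl in place of methyl on an amine nitrogen in a ring. Among the measured compounds shown here, no measured step touches this ring nitrogen, so the one known step gives no direct guidance; it shows only that the shared core tolerated a change elsewhere without a shift beyond the scatter. On that basis compound 3 is expected to stay near compound 1, with the step of a number 9.3 percentage points lower from compound 1 to compound 3 (within the scatter) estimated as small. In this assay compound 3 is estimated to give 82%, within a range from 60% to 96%.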

Compound 3, a percentage reported as inhibition, in the whole organism at one dose (the size of the read-out at that dose, not a potency): 84.4%
Estimate against measurement, compound 3: 2.4 percentage points below, within the range that was stated.
By their numbers in this assay, from the lowest: compounds 2, 3 and 1 (each within the scatter of the next).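

The ring nitrogen now has a measured step of its own: in this assay, phenyl in place of methyl gives a number 6.9 percentage points lower from compound 1 to compound 3 (within the scatter). This change replaces a group of 1 heavy atom with one of 6 heavy atoms and adds a six-membered aromatic ring of carbon only, yet at this single dose the read-out does not move beyond the usual scatter, so at this position the two groups cannot be told apart. Nothing measured here accounts for this result.

The compounds shown leave open how other groups on this ring nitrogen would behave, such as a plain hydrogen, an ethyl group, a benzyl group or a longer chain ending in a carboxylic acid or an amine. They also leave open whether phenyl on the ring nitrogen would give a similar reading alongside the 4-nitrophenyl group, and whether compounds that cannot be separated at this one dose would stay inseparable at lower doses.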